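Methyl to hydrogen on the aromatic oxygen of compound 2

A few compounds are considered here, and "the series" means these few. Any claim that something is new, unique, unknown or untested is made for them only; others in the source may bear on it.

Measured so far in a functional assay on DLD-1 cells (Homo sapiens) for cytotoxicity, read by resazurin assay, with a stated time of 48 h; on this read-out lower numbers stand for an effect already at smaller amounts and higher numbers for an effect only at larger amounts of compound:
compound 1 `O=S(=O)(Nc1ccc(-c2nc3cc(NS(=O)(=O)c4ccc(Cl)s4)ccc3o2)cc1)c1ccc(Cl)s1`: 33000 nM
compound 2 `COc1c(Br)cccc1C(=O)Nc1ccc(Sc2nc3ccccc3s2)c(Cl)c1`: 10000 nM
compound 3 `O=S(=O)(Nc1ccc(-c2nc3cc(NS(=O)(=O)c4ccc(C(F)(F)F)cc4)ccc3o2)cc1)c1ccc(C(F)(F)F)cc1`: 10000 nM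

Compound 2 and compound 3 give the same number at the digits shown, and together they sit at the lower end of the three values; compound 1 gives the higher number, and its gap to compound 2 lies beyond the scatter. Going by the values given here, no pair of measured compounds differs in a single place, so no measured step is available to guide the next change.

Compound 4 `O=C(Nc1ccc(Sc2nc3ccccc3s2)c(Cl)c1)c1cccc(Br)c1O` is the untested neighbour of compound 2. The change is hydrogen in place of methyl on an oxygen on an aromatic ring; more fully, methoxy becomes hydroxy, one carbon leaving and no ring or donor count otherwise stated.

Among the compounds with values here, with no comparable step in hand, the expectation for this assay is a step from compound 2 to compound 4 of a 1.3-fold lower number from compound 2 to compound 4 (0.10 log units; within the scatter), that is, little or none beyond the scatter, with a slight lean toward a lower number. Compound 4 is therefore estimated at 8000 nM, with a range from 2500 nM to 25000 nM, anchored to compound 2 at 10000 nM.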

Compound 4, half-maximal effective concentration: 22000 nM
Compound 4: the middle estimate sits 2.8-fold (0.44 log units) below what was measured, within the range that was stated.
By their numbers in this assay, from the lowest: compounds 2 and 3 (each within the scatter of the next); then compounds 4 and 1 (each within the scatter of the next).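

In this assay, removing the methyl from the aromatic oxygen is not neutral: a 2.2-fold higher number from compound 2 to compound 4 (0.34 log units; beyond the scatter). This gives the series its first single-place comparison and shows that this position responds to a small change, with methoxy giving the lower number of the two, though the step is modest. No supporting measurement on hand bears on the origin of this step.

From the compounds shown here alone, it remains open whether a longer chain on this oxygen, such as ethoxy, or an amine in place of the hydroxy of compound 4 would move the number further in either direction. Compound 1 and compound 3 differ from compound 2 in more than one place, so the position rests on this single step.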